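Swapping the sulfonyl ring group on compound 2

The compounds below may be only part of what the source reports. "The series", "measured", "known", "first", "only" and "open" are said of these compounds alone.

Measured in a physicochemical assay for lipophilicity, measured as octanol-water partition, at pH 7.4; on this read-out higher numbers stand for higher lipophilicity and lower numbers for lower lipophilicity:
- Compound 1 `Cc1ccc2[nH]c(C(=O)N[C@H]3CN(S(=O)(=O)c4cccnc4)C[C@@H]3C(=O)NCCN(C)C)cc2c1` gives 1.4
- Compound 2 `Cc1ccc2[nH]c(C(=O)N[C@H]3CN(S(=O)(=O)c4cnccn4)C[C@@H]3C(=O)NCCN(C)C)cc2c1` gives 1

Of these two, compound 2 stands lower, at 1. Compound 3 `Cc1ccc2[nH]c(C(=O)N[C@H]3CN(S(=O)(=O)c4ccnc(C)c4)C[C@@H]3C(=O)NCCN(C)C)cc2c1` differs from it in one place, with 2-methylpyridin-4-yl in place of pyrazin-2-yl on a sulfonyl sulfur. For the measured compounds named here, one measured step bears on this change: a number 0.40 log units lower from compound 1 to compound 2 (beyond the scatter), a modest move with pyrazin-2-yl in place of pyridin-3-yl. The new change runs the opposite way, from pyrazin-2-yl to a pyridinyl group that also carries a methyl, so a rise somewhat larger than that step is expected: a number 0.60 log units higher from compound 2 to compound 3 (beyond the scatter). For compound 3 the estimated value is 1.6, with an expected range from 1.2 to 2.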

Compound 3, distribution coefficient: 1.7
Compound 3: middle estimate off by 0.10 log units, on the low side, and the stated range covers the measured number.
By their numbers in this assay, from the lowest: compound 2; then compounds 1 and 3 (each within the scatter of the next).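

In this assay, putting 2-methylpyridin-4-yl on the sulfonyl sulfur in place of pyrazin-2-yl gives a number 0.70 log units higher from compound 2 to compound 3 (beyond the scatter) and more than reverses the earlier fall. Set against pyridin-3-yl, the same group gives a number 0.30 log units higher from compound 1 to compound 3 (within the scatter), so the two pyridinyl groups, one carrying a methyl, cannot be told apart on this read-out, and pyrazin-2-yl alone stands apart. No measured evidence at hand explains this difference. On these data alone, what a plain phenyl ring or a pyridin-4-yl group without the methyl would give on this sulfur stays open. So do the separate contributions of the methyl and of the ring nitrogen's place.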